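The source may report more compounds than this note shows. Statements on the series, on what has been measured and on what is new or still open speak of the compounds shown alone.

Three compounds have been measured in a functional assay on MCF7 cells (Homo sapiens) for antiproliferative activity, read by CellTiter-Glo, with a stated time of 5 days; on this read-out higher numbers stand for weaker inhibition and lower numbers for stronger inhibition:

compound 1, `N#Cc1ccc(/C(=C(\c2ccc(/C=C/C(=O)O)cc2)c2ccc3nccn3c2)C2CCC2)c(Cl)c1`, giving 15 nM
compound 2, `N#Cc1cc(Cl)ccc1/C(=C(\c1ccc(/C=C/C(=O)O)cc1)c1ccc2nccn2c1)C1CCC1`, giving 5.9 nM
compound 3, `N#Cc1ccc(/C(=C(\c2ccc(/C=C/C(=O)O)cc2)c2ccc(-c3cncs3)cc2)C2CCC2)c(Cl)c1`, giving 2.9 nM

Compound 3 stands lowest of the three, and its steps to both others are beyond the scatter. Compound 4, `N#Cc1cc(Cl)ccc1/C(=C(\c1ccc(/C=C/C(=O)O)cc1)c1ccc(-c2cncs2)cc1)C1CCC1`, has not yet been measured in this assay. It differs from compound 3 by 4-chloro-2-cyanophenyl in place of 2-chloro-4-cyanophenyl on a double-bonded chain carbon bound to a double-bonded chain carbon and a saturated ring carbon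

The same change has already been made once, from compound 1 to compound 2, where it is described as 4-chloro-2-cyanophenyl in place of 2-chloro-4-cyanophenyl on a double-bonded chain carbon bound to a double-bonded chain carbon and a saturated ring carbon

There it brought a 2.5-fold lower number from compound 1 to compound 2 (0.41 log units; beyond the scatter). The two cores on which the change is made differ as well: compound 3 carries a different group than compound 1, the difference being a group of 11 heavy atoms (9 carbon, 1 nitrogen, 1 sulfur; one five-membered aromatic ring with 2 hetero atoms, one six-membered aromatic ring of carbon only) in place of a group of 9 heavy atoms (7 carbon, 2 nitrogen; one five-membered aromatic ring with 2 hetero atoms, one six-membered aromatic ring with 1 hetero atom), on a double-bonded chain carbon bound to an aromatic carbon and a double-bonded chain carbon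

That core change itself brought a 5.2-fold lower number from compound 1 to compound 3 (0.71 log units; beyond the scatter). The place of the swap in compound 4 is worded exactly as in compound 2, so the account treats it as the same change rather than merely one of the same kind.

Because the swap gave a 2.5-fold lower number from compound 1 to compound 2 (0.41 log units; beyond the scatter) on the core of compound 1, a step of similar size is expected on the core of compound 3, and the estimated step is a 2.2-fold lower number from compound 3 to compound 4 (0.35 log units; beyond the scatter). This rests on a single earlier occurrence, so the range is kept wide. Compound 4 is therefore expected to give about 1.3 nM in this assay, most likely between 0.5 nM and 3.5 nM.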

Compound 4, half-maximal inhibitory concentration: 4.3 nM
Compound 4: middle estimate off by 3.3-fold (0.52 log units), on the low side, and the stated range ends below it.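

In this assay, the swap to 4-chloro-2-cyanophenyl did not carry over from one core to the other at its earlier size: it now gave a 1.5-fold higher number from compound 3 to compound 4 (0.17 log units; within the scatter), and the gap between this step and the earlier one is itself beyond the scatter: the same change on two cores in this assay, a 2.5-fold lower number (0.41 log units; beyond the scatter) from compound 1 to compound 2 and a 1.5-fold higher number (0.17 log units; within the scatter) from compound 3 to compound 4, 3.8-fold (0.58 log units) apart, beyond the scatter of two such steps

The exchange of the other group, read on the pair that carries the 4-chloro-2-cyanophenyl, gave a 1.4-fold lower number from compound 2 to compound 4 (0.14 log units; within the scatter), so it too lost the size it had on the pair that carries the 2-chloro-4-cyanophenyl: the same change on two cores in this assay, a 5.2-fold lower number (0.71 log units; beyond the scatter) from compound 1 to compound 3 and a 1.4-fold lower number (0.14 log units; within the scatter) from compound 2 to compound 4, 3.8-fold (0.58 log units) apart, beyond the scatter of two such steps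

Going by these compounds alone, this shows that in these four compounds the two changes do not simply add, and that the effect of the swap depends on the core it is made on; it does not show why, and with only two cores it does not show what the swap would do on any other core.

The compounds shown leave open whether a third core would follow the core of compound 1 or the core of compound 3. They also leave open how the swap would behave with a fluorine in place of the chlorine, or with a methyl ester in place of the carboxylic acid.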